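This account rests on a few compounds, and the source may have more. Where it says the series, first, only, none or still open, it means among the compounds named here.

Measured compounds in a functional assay on HT-1080 cells (Homo sapiens) for cytotoxicity, read by MTT assay, with a stated time of 72 h; on this read-out higher numbers stand for weaker inhibition and lower numbers for stronger inhibition:

compound 1, `N=C(Nc1cccc(C(F)(F)F)c1)c1cc2c(-c3ccccc3)n[nH]c2cn1`, gives 24600 nM
compound 2, `Cn1nc(-c2ccccc2)c2cc(C(=N)Nc3cccc(C(F)(F)F)c3)ncc21`, gives 17800 nM
compound 3, `N=C(Nc1cccc(C(F)(F)F)c1)c1cc2cn[nH]c2cn1`, gives 36500 nM

Compound 1 and compound 2 share one core and differ by methyl in place of hydrogen on an aromatic nitrogen; that change made the step of a 1.4-fold lower number from compound 1 to compound 2 (0.14 log units; within the scatter). The core of compound 3 differs from that of compound 1 by hydrogen in place of phenyl on an aromatic carbon, and this made the step of a 1.5-fold higher number from compound 1 to compound 3 (0.17 log units; within the scatter). Compound 3 and compound 2 are not compared by a single step here; their two numbers lie beyond the usual scatter of each other.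

Compound 4, `Cn1ncc2cc(C(=N)Nc3cccc(C(F)(F)F)c3)ncc21`, is not yet measured. It differs from compound 3 by methyl in place of hydrogen on an aromatic nitrogen. Within the data shown here, this is the same kind of change as the one from compound 1 to compound 2, but not the same: in the earlier pair the place lies two ring bonds from the ring atom that bears a phenyl group, whereas in compound 3 and compound 4 that ring atom carries hydrogen. In this assay the step from compound 3 to compound 4 is expected to be about a 1.4-fold lower number from compound 3 to compound 4 (0.15 log units; within the scatter), resting on the step of a 1.4-fold lower number from compound 1 to compound 2 (0.14 log units; within the scatter), which stayed within the scatter. The number expected for compound 4 is therefore 26000 nM, estimated to fall between 15000 nM and 50000 nM.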

Compound 4, half-maximal inhibitory concentration: 33800 nM
Beside the measured number, compound 4's estimate is 1.3-fold (0.11 log units) below it, within the range that was stated.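

In this assay, methyl in place of hydrogen on an aromatic nitrogen gave a 1.1-fold lower number from compound 3 to compound 4 (0.03 log units; within the scatter), and this step can be set beside the same change on the core that carries phenyl: the same change on two cores in this assay, a 1.4-fold lower number (0.14 log units; within the scatter) from compound 1 to compound 2 and a 1.1-fold lower number (0.03 log units; within the scatter) from compound 3 to compound 4, 1.3-fold (0.11 log units) apart, within the scatter of two such steps. Hydrogen in place of phenyl on an aromatic carbon gave a 1.9-fold higher number from compound 2 to compound 4 (0.28 log units; within the scatter), and this step too matches its counterpart on the other core: the same change on two cores in this assay, a 1.5-fold higher number (0.17 log units; within the scatter) from compound 1 to compound 3 and a 1.9-fold higher number (0.28 log units; within the scatter) from compound 2 to compound 4, 1.3-fold (0.11 log units) apart, within the scatter of two such steps. So each of the two changes carried over between these two cores without a gap beyond the scatter, but every one of these steps also lies within the scatter, so the agreement shows only that neither change moved the number measurably in these pairs, not that either has a real effect of a transferable size, and it rests on a single pair of cores in one cell assay.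

The compounds shown hold only hydrogen or methyl on that aromatic nitrogen and only hydrogen or phenyl on that aromatic carbon, so it stays open how a longer chain such as ethyl on the nitrogen, or an amine or a carboxylic acid on the carbon, would read. All four compounds also keep the trifluoromethyl group, so what replacing it with a chlorine atom or a methoxy group would do is open as well.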